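Methylpiperazine replacing methylpiperidine on the aminomethyl chain

This account rests on a few compounds, and the source may have more. Where it says the series, first, only, none or still open, it means among the compounds named here.

Compound 1 `COc1cc(Cc2cnc(/N=C3\C(=O)N(CN4CCCCC4C)c4ccc(Cl)cc43)nc2N)cc(OC)c1OC` shows in an ADME assay on CCRF-CEM cells (Homo sapiens) for cytotoxicity, read by MTT assay, with a stated time of 5 days (a lower number here means that less compound is tolerated, a higher number that more compound is tolerated), only a limit, namely > 83.8 ug/mL. As far as these compounds go, that places compound 1 at the limit of > 83.8 ug/mL in this assay, at which 1 of the 3 values shown sits, so its true position on the numbers remains open. Compound 2 `COc1cc(Cc2cnc(/N=C3\C(=O)N(CN4CCN(Cc5ccccc5)CC4)c4ccc(Cl)cc43)nc2N)cc(OC)c1OC` gives 94.7 ug/mL in this assay, and compound 3 `COc1cc(Cc2cnc(/N=C3\C(=O)N(CN(Cc4ccccc4)Cc4ccccc4)c4ccc(Cl)cc43)nc2N)cc(OC)c1OC` gives 37.1 ug/mL. Among the measured compounds shown here, none of these three differ in a single place, so no measured single-point step is available. Compound 4 `COc1cc(Cc2cnc(/N=C3\C(=O)N(CN4CCN(C)CC4)c4ccc(Cl)cc43)nc2N)cc(OC)c1OC` carries 4-methylpiperazin-1-yl in place of 2-methylpiperidin-1-yl on a saturated chain carbon bound to an amide-type nitrogen in a ring. In this assay a step of no size beyond the usual scatter is expected for this exchange, in either direction; the expected step reads a step that the limit leaves unreadable from compound 1 to compound 4. Compound 4 is accordingly estimated at 90 ug/mL, with a range from 40 ug/mL to 160 ug/mL, and a limit rather than a number would not surprise.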

Compound 4, half-maximal cytotoxic concentration: 88 ug/mL
For compound 4 the middle estimate is 1.0-fold (0.01 log units) above the measured one; the measured number falls inside the stated range.
By their numbers in this assay, from the lowest: compound 3; then compounds 4 and 2 (each within the scatter of the next).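

Among the compounds shown here, the first readable single-place step in this assay comes from the piperazine pair: hydrogen in place of phenyl on a saturated chain carbon bound to an amine nitrogen in a ring gives a 1.1-fold lower number from compound 2 to compound 4 (0.03 log units; within the scatter). At this place, the phenyl can therefore go without a change beyond the scatter. Compound 1 carries only a limit, so the step from the 2-methylpiperidin-1-yl group to the 4-methylpiperazin-1-yl group cannot be read: the limit of > 83.8 ug/mL in this assay, at which 1 of the 4 values shown sits.

As far as these compounds go, how a morpholin-4-yl group in this place would read stays open. So does the effect of a longer chain or a carboxylic acid on the piperazine nitrogen.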